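This account rests on a few compounds, and the source may have more. Where it says the series, first, only, none or still open, it means among the compounds named here.

Working notes on the series. In an ADME assay on HEK293 cells (Homo sapiens) for cytotoxicity, read by reporter gene assay and resazurin assay, with a stated time of 48 h (a higher number here means that more compound is tolerated, a lower number that less compound is tolerated), compound 2 `COc1ccccc1C(=O)Nc1ccc(Sc2nc3ccccc3s2)cc1` reads > 100000 nM, which is a limit and not a number. Compound 3 `COc1ccccc1C(=O)Nc1cccc(Cl)c1` reads > 100000 nM, also a limit. Compound 2 thus stands at the limit of > 100000 nM in this assay, at which 2 of the 3 values shown sit. Compound 4 `O=C(Nc1ccc(Sc2nc3ccccc3s2)cc1)c1ccccc1O` differs from it by hydrogen in place of methyl on an oxygen on an aromatic ring, which turns methoxy to hydroxy. Within the data shown here, no measured pair shows this change alone. Compound 1 `O=C(Nc1ccccc1)c1cc(Br)ccc1O` carries a hydroxy on an aromatic ring and gives 35000 nM, so a moderate step toward less compound tolerated is expected in this assay. The expected size of the move is an at least 2.8-fold lower number from compound 2 to compound 4 (0.45 log units; beyond the scatter). The estimated value for compound 4 is 35000 nM, with an expected range of 10000 nM to 100000 nM.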

Compound 4, half-maximal cytotoxic concentration: 74000 nM
For compound 4 the middle estimate is 2.1-fold (0.33 log units) below the measured one; the range from low to high includes it.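

In this assay, methoxy to hydroxy on an aromatic ring now has a measured pair, with an at least 1.3-fold lower number from compound 2 to compound 4 (0.13 log units; that floor lies within the scatter). That floor alone does not establish a real loss of tolerated compound, and the hydroxy compound still gives a finite reading. The true size of the step remains unknown because one end of it is a limit: the limit of > 100000 nM in this assay, at which 2 of the 4 values shown sit.

The compounds shown leave open how an amine or a carboxylic acid in place of the hydroxy would read. They also leave open whether the same change would give a comparable step on another core.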